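Swapping a thiophene for a methoxyphenoxy group on a shared core

The compounds below may be only part of what the source reports. "The series", "measured", "known", "first", "only" and "open" are said of these compounds alone.

Measured so far:
compound 1 `Cc1ccccc1-n1nc(C)c2c1NC(=O)[C@H](C)S[C@@H]2c1ccc(-c2ccsc2)cc1`: 1400 nM
compound 2 `Cc1cccc(-n2nc(C)c3c2NC(=O)[C@H](C)S[C@@H]3c2ccc(Oc3ccccc3)cc2)c1`: 2400 nM

In an assay on isolated protein for agonist activity at Bile acid receptor (Homo sapiens), read by AlphaScreen, with a stated time of 30 min (on this read-out higher numbers stand for an effect only at larger amounts of compound and lower numbers for an effect already at smaller amounts), compound 1 gives 1400 nM, and compound 2 gives 2400 nM; the two numbers lie within the usual scatter of each other, so neither is set apart. Compound 3 `COc1cccc(Oc2ccc([C@H]3S[C@@H](C)C(=O)Nc4c3c(C)nn4-c3ccccc3C)cc2)c1` differs from compound 1 in one place: 3-methoxyphenoxy in place of thiophen-3-yl on an aromatic carbon. Going by the values given here, no measured pair shows this change, so only a cautious guess is possible. Compound 2 also carries a phenoxy group at this place and gives 2400 nM, which suggests that the step of a 1.4-fold higher number from compound 1 to compound 3 (0.15 log units; within the scatter) is expected to stay within the scatter. Compound 3 is therefore estimated at 2000 nM, in a range from 700 nM to 6000 nM.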

Compound 3, half-maximal effective concentration: 1700 nM
Estimate against measurement, compound 3: 1.2-fold (0.07 log units) above; measured number inside the range.
By their numbers in this assay, from the lowest: compounds 1, 3 and 2 (each within the scatter of the next).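

In this assay, the place on the aromatic carbon para to a large group accepts 3-methoxyphenoxy in place of thiophen-3-yl with no step beyond the scatter (a 1.2-fold higher number from compound 1 to compound 3 (0.08 log units; within the scatter)). So a six-membered carbon ring joined through oxygen, with 9 heavy atoms instead of 5, reads the same here as the five-membered sulfur ring. No data shown explain this result.

Still open, on these data alone, is whether an amine or a carboxylic acid at this place would give a number beyond the scatter. The compounds shown also cannot separate the methoxy's contribution from that of the phenoxy carrying it.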